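The source may hold more compounds than are shown below. What is called first, only, known or untested is meant among the compounds shown, and "the series" means these compounds.

Measured compounds:
compound 1 `Cc1cc(-c2ccco2)c(S(C)(=O)=O)cc1C(=O)N=C(N)N` gives 16 nM
compound 2 `Cc1cc(Sc2ccccc2Cl)c(S(C)(=O)=O)cc1C(=O)N=C(N)N` gives 14 nM

In a functional assay for inhibition of sodium/hydrogen exchanger (Oryctolagus cuniculus) (a higher number here means a weaker inhibitor, a lower number a stronger inhibitor), compound 2 has the lowest of the two numbers, yet it stands within the scatter of compound 1, so the two cannot be ranked. Among the compounds with values here, the one measured step, a 1.1-fold lower number from compound 1 to compound 2 (0.06 log units; within the scatter), exchanged one substituent for another at this position without moving the read-out beyond the scatter. Compound 3 `CCOc1cc(C)c(C(=O)N=C(N)N)cc1S(C)(=O)=O` carries the change (ethoxy in place of (2-chlorophenyl)sulfanyl on an aromatic carbon). Within the data shown here, the only step that bears on it is the one from compound 1 to compound 2, and it was flat. Among the measured compounds shown here, for compound 3 the expectation is therefore a step of a 2.9-fold higher number from compound 2 to compound 3 (0.46 log units; beyond the scatter), a mild weakening, because the replacing group is far smaller than either group seen in a 1.1-fold lower number from compound 1 to compound 2 (0.06 log units; within the scatter) and no measured compound shows what that does. Compound 3 is estimated at 40 nM, with a range from 10 nM to 200 nM.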

Compound 3, half-maximal inhibitory concentration: 19 nM
Estimate against measurement, compound 3: 2.1-fold (0.32 log units) above; the range from low to high includes it.
By their numbers in this assay, from the lowest: compounds 2, 1 and 3 (each within the scatter of the next).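

In this assay, ethoxy on this aromatic carbon, ortho to a methylsulfonyl group, gives a 1.4-fold higher number from compound 2 to compound 3 (0.13 log units; within the scatter) when it replaces (2-chlorophenyl)sulfanyl, and a 1.2-fold higher number from compound 1 to compound 3 (0.07 log units; within the scatter) when it replaces furan-2-yl. The earlier pair both carried a ring in this substituent, whereas ethoxy has no ring and only 3 heavy atoms, so among these three compounds neither a ring nor the larger size of the substituent is needed to keep the read-out in the same range. Nothing available explains why the three substituents read alike.

The compounds shown leave open whether this position also accepts an amine, a carboxylic acid or a chain longer than ethoxy, and whether plain hydrogen would keep the read-out. They also leave open whether the same insensitivity holds once the methyl group of the shared core is exchanged.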